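Moving a Chloro Around the Benzyl Ring

This account rests on a few compounds, and the source may have more. Where it says the series, first, only, none or still open, it means among the compounds named here.

Measured in a functional assay on MCF7 cells (Homo sapiens) for antiproliferative activity, read by MTT assay, with a stated time of 72 h; a lower number here means a stronger inhibitor, a higher number a weaker inhibitor:
compound 1, `CCCSc1nc(N/N=C(\C)c2ccccc2O)c2nnn(Cc3ccc(Cl)cc3)c2n1`: 42600 nM
compound 2, `CCCSc1nc(N/N=C(\C)c2ccccc2O)c2nnn(Cc3ccccc3)c2n1`: 11000 nM

Going by the values given here, compound 2 holds the lowest of these two numbers, and its only neighbour is compound 1, separated by a 3.9-fold lower number from compound 1 to compound 2 (0.59 log units; beyond the scatter). Compound 3, `CCCSc1nc(N/N=C(\C)c2ccccc2O)c2nnn(Cc3cccc(Cl)c3)c2n1`, differs from compound 2 by chloro in place of hydrogen on an aromatic carbon. Among the compounds with values here, the one step that bears on this change, a 3.9-fold lower number from compound 1 to compound 2 (0.59 log units; beyond the scatter), removed a chloro from the same benzyl ring, though at a different carbon, and gave a modest gain. Putting a chloro back, at a new carbon, is therefore expected to reverse part of that gain, with a modest rise of a 2.3-fold higher number from compound 2 to compound 3 (0.36 log units; beyond the scatter) in this assay. Compound 3 is estimated at 25000 nM, within 9000 nM to 70000 nM.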

Compound 3, half-maximal inhibitory concentration: 39900 nM
Compound 3: middle estimate off by 1.6-fold (0.20 log units), on the low side; measured number inside the range.
By their numbers in this assay, from the lowest: compound 2; then compounds 3 and 1 (each within the scatter of the next).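

In this assay, the 3-chlorobenzyl group gives up the gain of the plain benzyl group (a 3.6-fold higher number from compound 2 to compound 3 (0.56 log units; beyond the scatter)), so the cost of a chloro on this ring is not tied to one carbon. Shifting the chloro between the two carbons changes nothing that can be told (a 1.1-fold lower number from compound 1 to compound 3 (0.03 log units; within the scatter)), so among these three compounds it is the presence of the chloro that counts, not its carbon. As far as these compounds go, whether a fluoro, a methyl or a methoxy on these carbons would raise the number as chloro does remains open. No evidence at hand accounts for this result.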